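A few compounds are considered here, and "the series" means these few. Any claim that something is new, unique, unknown or untested is made for them only; others in the source may bear on it.

Compound 1 `COc1cccc(C(=O)Nc2cc(-c3ccccc3)nn2-c2ccccc2)c1` gives 1290 nM in an assay on HEK293 cells for displacement of a labelled ligand from metabotropic glutamate receptor 5 (Rattus norvegicus) (on this read-out lower numbers stand for stronger inhibition and higher numbers for weaker inhibition), the highest of the three numbers measured, though compound 3 sits within the scatter of it. Compound 2 `COc1ccc(C(=O)Nc2cc(-c3ccccc3)nn2-c2ccccc2)cc1` gives 420 nM and compound 3 `O=C(Nc1cc(-c2ccccc2)nn1-c1ccccc1)c1ccc(C(F)(F)F)cc1` gives 990 nM. Within this set, a 3.1-fold lower number from compound 1 to compound 2 (0.49 log units; beyond the scatter) and a 1.3-fold lower number from compound 1 to compound 3 (0.11 log units; within the scatter), while a 2.4-fold higher number from compound 2 to compound 3 (0.37 log units; beyond the scatter). Compound 4 `O=C(Nc1cc(-c2ccccc2)nn1-c1ccccc1)c1ccc(Cl)c(Cl)c1` differs from compound 1 by 3,4-dichlorophenyl in place of 3-methoxyphenyl on a carbonyl carbon. Both measured steps from compound 1 also replace the 3-methoxyphenyl with a differently substituted phenyl on the carbonyl carbon; one lowered the number modestly and the other stayed within the scatter, so at most a modest lowering is expected here in this assay. Compound 4 is therefore estimated at 650 nM, with a range of 250 nM to 1600 nM, which would mean a 2.0-fold lower number from compound 1 to compound 4 (0.30 log units; within the scatter).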

Compound 4, inhibition constant: 160 nM
Compound 4: the middle estimate sits 4.1-fold (0.61 log units) above what was measured; measured number below the stated range.
By their numbers in this assay, from the lowest: compound 4; then compound 2; then compounds 3 and 1 (each within the scatter of the next).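

In this assay, 3,4-dichlorophenyl on the carbonyl carbon gives an 8.1-fold lower number from compound 1 to compound 4 (0.91 log units; beyond the scatter), along with a 6.2-fold lower number from compound 3 to compound 4 (0.79 log units; beyond the scatter) and a 2.6-fold lower number from compound 2 to compound 4 (0.42 log units; beyond the scatter), so compound 4 is the most potent of the four. A lower number at this place therefore does not require a hydrogen-bond acceptor in the entering group, as 3,4-dichlorophenyl has none. Nothing available explains the gain.

As far as these compounds go, it remains open whether a single chlorine on the phenyl ring keeps this gain or both are needed. How an amine or a carboxylic acid on that ring would fare is also unknown.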